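The source may hold more compounds than are shown below. What is called first, only, known or untested is meant among the compounds shown, and "the series" means these compounds.

Working notes on the series. Compound 1 `Cc1ccccc1N1CCC(=O)N1` and compound 2 `Cc1cccc(N2CCC(=O)N2)c1` carry the same atoms joined differently; the difference between the two cores is not broken down here. In an assay on isolated protein for inhibition of Polyunsaturated fatty acid 5-lipoxygenase (Homo sapiens) (on this read-out lower numbers stand for stronger inhibition and higher numbers for weaker inhibition), compound 1 gives 8200 nM, while compound 2 gives 1300 nM, the lowest number of the three measured and beyond the scatter from both others. Compound 3 `O=C1CCN(c2ccccc2Cl)N1` differs from compound 1 by a single change, (chloro in place of methyl on an aromatic carbon); in this assay compound 3 gives 3700 nM, so the step is a 2.2-fold lower number from compound 1 to compound 3 (0.35 log units; beyond the scatter). Compound 4 `O=C1CCN(c2cccc(Cl)c2)N1` is not yet measured and differs from compound 2 by chloro in place of methyl on an aromatic carbon. This is the same kind of change as that from compound 1 to compound 3, but not the same: in compound 3 the chloro sits ortho to a group of 6 heavy atoms, in compound 4 it sits meta to a group of 6 heavy atoms. The change occurs twice among these compounds, once with a measurement. For compound 4 a step of about a 2.2-fold lower number from compound 2 to compound 4 (0.34 log units; beyond the scatter) in this assay is expected. Going by the values given here, this expectation rests only on the one measured step of a 2.2-fold lower number from compound 1 to compound 3 (0.35 log units; beyond the scatter) and on compound 2 at 1300 nM. Compound 4 is therefore estimated at 600 nM, with a range from 300 nM to 1500 nM.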

Compound 4, half-maximal inhibitory concentration: 730 nM
Beside the measured number, compound 4's estimate is 1.2-fold (0.09 log units) below it, and the stated range covers the measured number.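

In this assay the new step is a 1.8-fold lower number from compound 2 to compound 4 (0.25 log units; within the scatter), so on the core of compound 2 the exchange of methyl for chloro does not by itself stand clear of the scatter. Set beside the earlier step, the exchange carries from one core to the other with no difference that can be told apart: the same change on two cores in this assay, a 2.2-fold lower number (0.35 log units; beyond the scatter) from compound 1 to compound 3 and a 1.8-fold lower number (0.25 log units; within the scatter) from compound 2 to compound 4, 1.2-fold (0.09 log units) apart, within the scatter of two such steps. This agreement rests on just two pairs, so it does not show that the step would hold on any further core, nor does it fix a general size for the exchange.

The compounds shown carry only methyl or chloro on the aromatic ring, which leaves open how an amine, a carboxylic acid or a methoxy group in the same place would read in this assay. Also open, going by these compounds, is whether a longer chain in place of methyl or chloro would stay in line with these two steps.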